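From amide to free acid on a pivaloylated core

The source may report more compounds than this note shows. Statements on the series, on what has been measured and on what is new or still open speak of the compounds shown alone.

Compound 2 `CC(C)=CCC[C@H](C)[C@H]1c2cc(C(=O)NCCN(C)C)c(OC(=O)C(C)(C)C)c(OC(=O)C(C)(C)C)c2[C@H](C)C[C@H]1OC(=O)C(C)(C)C` stands as the lowest of the two numbers in an ADME assay on HEK293 cells (Homo sapiens) for inhibition, read by resazurin assay, with a stated time of 72 h (on this read-out higher numbers stand for weaker inhibition and lower numbers for stronger inhibition), where compound 2 gives 14600 nM. For the measured compounds named here, compound 1 `CC(C)=CCC[C@H](C)[C@H]1c2cc(C(=O)NCc3ccc(Br)cc3)c(OC(=O)C(C)(C)C)c(OC(=O)C(C)(C)C)c2[C@H](C)C[C@H]1OC(=O)C(C)(C)C` in this assay gives 40000 nM, and a 2.7-fold lower number from compound 1 to compound 2 (0.44 log units; beyond the scatter) is the only measured step. Compound 3 `CC(C)=CCC[C@H](C)[C@H]1c2cc(C(=O)O)c(OC(=O)C(C)(C)C)c(OC(=O)C(C)(C)C)c2[C@H](C)C[C@H]1OC(=O)C(C)(C)C` differs from compound 2 by hydroxy in place of (2-(dimethylamino)ethyl)amino on a carbonyl carbon. That change alters the carbonyl substituent itself, whereas the measured step only exchanged one group on a saturated chain carbon bound to an amide-type nitrogen, so it bears on the new step only loosely. The expected step is a 2.1-fold higher number from compound 2 to compound 3 (0.31 log units; beyond the scatter), toward a higher number. Compound 3 is accordingly estimated at 30000 nM, within a range from 10000 nM to 100000 nM.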

Compound 3, half-maximal inhibitory concentration: 40000 nM
Compound 3: middle estimate off by 1.3-fold (0.12 log units), on the low side, within the range that was stated.
By their numbers in this assay, from the lowest: compound 2; then compounds 1 and 3 (each within the scatter of the next).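

At the carbonyl carbon, hydroxy in place of (2-(dimethylamino)ethyl)amino gives a 2.7-fold higher number from compound 2 to compound 3 (0.44 log units; beyond the scatter) and so gives up the lower number held by compound 2. Hydroxy in place of (4-bromobenzyl)amino gives no change at the digits printed from compound 1 to compound 3 (within the scatter) in the same read-out, so of these three carbonyl substituents only the (2-(dimethylamino)ethyl)amino group stands apart. Nothing available explains this result.

As far as these compounds go, whether a longer chain ending in a dimethylamino group, or a primary amine on the same chain, would move the number further stays open. So does how an unsubstituted amide at this carbonyl carbon would compare.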